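The source may report more compounds than this note shows. Statements on the series, on what has been measured and on what is new or still open speak of the compounds shown alone.

Measured so far:
compound 2, `O=C(NCCCCc1ccccc1)c1cccc(C2SCC(=O)N2c2ccccc2F)c1`: 80%
compound 1, `COc1ccc(OC)c(N2C(=O)CSC2c2cccc(C(=O)NCCCCc3ccccc3)c2)c1`: 48%

Both compounds were tested in a functional assay on SJSA-1 cells (Homo sapiens) for inhibition, read by CCK-8 assay, with a stated time of 72 h, tested at 1 uM; a higher number here means more inhibition at the concentration tested (going by the name of the read-out), a lower number less inhibition. Compound 2 gives the higher of the two numbers, 80%, while compound 1 gives 48%. For the measured compounds named here, the only measured step, a number 32 percentage points higher from compound 1 to compound 2 (beyond the scatter), is large and lies beyond the scatter, so the group on the amide-type nitrogen in the ring clearly matters for this read-out.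

Compound 3 is `CC(F)(F)c1cccc(N2C(=O)CSC2c2cccc(C(=O)NCCCCc3ccccc3)c2)c1`. It differs from compound 2 only at that same position: a group of 10 heavy atoms (8 carbon, 2 fluorine; one six-membered aromatic ring of carbon only) in place of a group of 7 heavy atoms (6 carbon, 1 fluorine; one six-membered aromatic ring of carbon only), on an amide-type nitrogen in a ring. The measured step bears on it in that it touches the same place, but it exchanges a different pair of groups, so it cannot be carried over directly. Going by the values given here, only one step is known, and nothing shows how a larger fluorine-bearing group at this position behaves. The expected step of a number 15 percentage points lower from compound 2 to compound 3 (beyond the scatter) is therefore set near no change, with wide uncertainty. Compound 3 is estimated at 65%, within a range from 35% to 90%.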

Compound 3, a percentage reported as inhibition, at one concentration (the size of the read-out at that concentration, not a potency) in the SJSA-1 assay: 68%
Estimate against measurement, compound 3: 3 percentage points below; the range from low to high includes it.
By their numbers in the SJSA-1 assay, from the lowest: compound 1; then compound 3; then compound 2.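

At this position, two groups with the same heavy-atom count do not give the same result: in the SJSA-1 assay compound 1 gives 48% and compound 3 gives 68% with a number 20 percentage points higher from compound 1 to compound 3 (beyond the scatter), so heavy-atom count alone does not set the number, and the atoms carried by the group count as well. Moving from the 2-fluorophenyl to the larger group with two fluorines costs some inhibition, with a number 12 percentage points lower from compound 2 to compound 3 (beyond the scatter), but the number stays well clear of the one for the dimethoxyphenyl compound, so this position accepts more than one fluorine-bearing group. In a physicochemical assay for solubility, read by turbidimetry, measured as kinetic solubility, at pH 6.8 (on this read-out higher numbers stand for higher solubility and lower numbers for lower solubility), compound 2 gives 20000 nM and compound 3 gives 10000 nM with a 2.0-fold lower number from compound 2 to compound 3 (0.30 log units; within the scatter), so these two compounds cannot be told apart on solubility, and nothing at hand explains any of these differences.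

Three compounds cannot show whether fluorine itself matters, and a plain phenyl, or a phenyl carrying an amine or a carboxylic acid at this position, would help separate the effect of the atoms from that of group size. Going by these compounds, each inhibition number also comes from a single concentration, so how these compounds rank in potency across a range of concentrations remains open.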